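Cyclobutylcarbamoyl to (dimethylamino)methyl on the side chain

The compounds below may be only part of what the source reports. "The series", "measured", "known", "first", "only" and "open" are said of these compounds alone.

Going by the values given here, compound 3 `Cn1ncc(Cl)c1-c1cc(C(=O)N[C@@H]2CN[C@H](CC(=O)NC3CCC3)C[C@H]2c2ccc(Cl)c(Cl)c2)oc1Cl` gives 7.98 nM in an assay for inhibition of RAC-alpha serine/threonine-protein kinase (Homo sapiens), read by HTRF, with a stated time of 1 h (a higher number here means a weaker inhibitor, a lower number a stronger inhibitor), the highest of the three numbers measured so far. Compound 1 `COCC[C@@H]1C[C@@H](c2ccc(Cl)c(Cl)c2)[C@H](NC(=O)c2cc(-c3c(Cl)cnn3C)c(Cl)o2)CN1` gives 7.01 nM, and the step of a 1.1-fold higher number from compound 1 to compound 3 (0.06 log units; within the scatter) stays within the scatter; compound 2 `Cn1ncc(Cl)c1-c1cc(C(=O)N[C@@H]2CN[C@H](CC(=O)NCC(O)CO)C[C@H]2c2ccc(Cl)c(Cl)c2)oc1Cl` gives 3.13 nM, and the step of a 2.5-fold higher number from compound 2 to compound 3 (0.41 log units; beyond the scatter) lies beyond it. Compound 4 `CN(C)CC[C@@H]1C[C@@H](c2ccc(Cl)c(Cl)c2)[C@H](NC(=O)c2cc(-c3c(Cl)cnn3C)c(Cl)o2)CN1` differs from compound 3 in one place: (dimethylamino)methyl in place of cyclobutylcarbamoyl on a saturated chain carbon bound to a saturated ring carbon. Among the compounds with values here, no measured step introduces this entering group. The closest precedents are a 1.1-fold higher number from compound 1 to compound 3 (0.06 log units; within the scatter), where a different chain at the same place changed little, and a 2.5-fold higher number from compound 2 to compound 3 (0.41 log units; beyond the scatter), a modest shift. A step no larger than modest is therefore expected: a 1.3-fold lower number from compound 3 to compound 4 (0.12 log units; within the scatter). The estimate for compound 4 is 6 nM, with a range from 2.5 nM to 15 nM.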

Compound 4, half-maximal inhibitory concentration: 3.4 nM
Compound 4: middle estimate off by 1.8-fold (0.25 log units), on the high side; low and high end bracket the measured number.
By their numbers in this assay, from the lowest: compounds 2 and 4 (each within the scatter of the next); then compounds 1 and 3 (each within the scatter of the next).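

Placing (dimethylamino)methyl on this chain gives a 2.3-fold lower number from compound 3 to compound 4 (0.37 log units; beyond the scatter), and replacing methoxy with dimethylamino gives a 2.1-fold lower number from compound 1 to compound 4 (0.31 log units; beyond the scatter), both modest steps. Against the diol amide the result is a 1.1-fold higher number from compound 2 to compound 4 (0.04 log units; within the scatter), so a carbamoyl group is not required at this place to reach the level of compound 2, and a short chain ending in an amine does as well. Nothing available explains these shifts. Going by these compounds, it remains open whether another amine, such as pyrrolidine or a primary amine, would do the same. On these data alone, a longer chain carrying the dimethylamino group is equally open.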